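The compounds below may be only part of what the source reports. "The series", "measured", "known", "first", "only" and "open" are said of these compounds alone.

Three compounds that share one core and differ only in the group on an aromatic nitrogen have been tested in a functional assay on MCF7 cells (Homo sapiens) for cytotoxicity, read by MTT assay, with a stated time of 96 h; a lower number here means a stronger inhibitor, a higher number a weaker inhibitor. Compound 2 `COc1cc(C(=O)c2cn(-c3cccc(Br)c3)cc2-c2ccccc2)cc(OC)c1OC` gives 78 nM, compound 3 `COc1ccc(-n2cc(C(=O)c3cc(OC)c(OC)c(OC)c3)c(-c3ccccc3)c2)cc1` gives 120 nM, and compound 1 `COc1cc(C(=O)c2cn(-c3ccccc3N)cc2-c2ccccc2)cc(OC)c1OC` gives 3800 nM. Compound 2 has the lowest number of the three, but it is not separated from compound 3: the measured difference is a 1.5-fold higher number from compound 2 to compound 3 (0.19 log units; within the scatter). Only compound 1 stands well apart, with a 49-fold lower number from compound 1 to compound 2 (1.69 log units; beyond the scatter) and a 32-fold lower number from compound 1 to compound 3 (1.50 log units; beyond the scatter), both large.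

The next compound to be measured is compound 4 `COc1cc(C(=O)c2cn(-c3cc(OC)c(OC)c(OC)c3)cc2-c2ccccc2)cc(OC)c1OC`. It keeps the core of compound 2 and changes one group on the aromatic nitrogen: 3,4,5-trimethoxyphenyl in place of 3-bromophenyl on an aromatic nitrogen. Among the measured compounds shown here, no tested compound carries 3,4,5-trimethoxyphenyl, so any forecast is indirect. The nearest guide is compound 3, whose 4-methoxyphenyl group is the closest match, and exchanging 3-bromophenyl for that group gave only a 1.5-fold higher number from compound 2 to compound 3 (0.19 log units; within the scatter). The large steps from compound 1 are a warning that a change at this place can matter a great deal, so the range has to stay wide. The expected change in this assay is small and leans towards a higher number: a 1.9-fold higher number from compound 2 to compound 4 (0.28 log units; within the scatter). For compound 4 the estimated value is 150 nM, with an expected range from 40 nM to 600 nM.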

Compound 4, half-maximal inhibitory concentration: > 5000 nM
Compound 4 ended at the assay's limit (the forecaster's own chance of this, stated with the estimate: 5%); middle value at least 33-fold (1.52 log units) from the limit.
By their numbers in this assay, from the lowest: compounds 2 and 3 (each within the scatter of the next); then compound 1. At a limit, above all of these: compound 4.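

In this assay compound 4 gives > 5000 nM, which is a limit of the assay and not a number. Among the compounds shown here, until now, the only group on the aromatic nitrogen that had cost much was the 2-aminophenyl of compound 1, while 3-bromophenyl and 4-methoxyphenyl gave values within the scatter of each other, so a phenyl ring carrying a methoxy group seemed acceptable here; 3,4,5-trimethoxyphenyl shows that this does not extend to every methoxy-bearing ring, with an at least 64-fold higher number from compound 2 to compound 4 (1.80 log units; beyond the scatter) and an at least 41-fold higher number from compound 3 to compound 4 (1.61 log units; beyond the scatter). A large loss at this place therefore does not need an amine on the ring, although compound 4 cannot be ranked firmly against compound 1, since the comparison gives only a floor that lies within the scatter: an at least 1.3-fold higher number from compound 1 to compound 4 (0.11 log units; that floor lies within the scatter).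

These four compounds do not tell whether a dimethoxyphenyl group would already bring the loss or whether it takes all three methoxy groups. They also leave open where a plain phenyl group would fall, and how far past the limit of the assay compound 4 really lies.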